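Swapping the pyrazole substituent: from cyclopropyl to oxan-4-yl

The compounds below may be only part of what the source reports. "The series", "measured", "known", "first", "only" and "open" are said of these compounds alone.

Of the compounds shown here, three sharing the same core have been measured in an assay on isolated protein for inhibition of serine/threonine-protein kinase TBK1 (Homo sapiens); on this read-out lower numbers stand for stronger inhibition and higher numbers for weaker inhibition. Compound 1 `CC(C)n1cc(Nc2ncc(C3CC3)c(NCCCNC(=O)C3CCC3)n2)cn1` gives 4 nM, compound 2 `O=C(NCCCNc1nc(Nc2cncnc2)ncc1C1CC1)C1CCC1` gives 3200 nM, and compound 3 `O=C(NCCCNc1nc(Nc2cnn(C3CC3)c2)ncc1C1CC1)C1CCC1` gives 10 nM. Compound 3 therefore stands second of the three: it is separated from compound 1 by a small step, a 2.5-fold higher number from compound 1 to compound 3 (0.40 log units; beyond the scatter), and from compound 2 by a very large one, a 320-fold lower number from compound 2 to compound 3 (2.51 log units; beyond the scatter).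

Compound 4 `O=C(NCCCNc1nc(Nc2cnn(C3CCOCC3)c2)ncc1C1CC1)C1CCC1` is not yet measured. It differs from compound 3 in one spot: oxan-4-yl in place of cyclopropyl on an aromatic nitrogen. Among the compounds with values here, the only measured step that bears on this kind of change is the exchange of the group on the pyrazole nitrogen, a 2.5-fold higher number from compound 1 to compound 3 (0.40 log units; beyond the scatter), which was modest. The much larger steps an 800-fold higher number from compound 1 to compound 2 (2.90 log units; beyond the scatter) and a 320-fold lower number from compound 2 to compound 3 (2.51 log units; beyond the scatter) involved replacing the whole aromatic ring, so they do not speak directly to the present change. For compound 4 a modest shift in this assay is expected, no change at the digits printed from compound 3 to compound 4 (within the scatter), with the estimate for compound 4 at 10 nM and a range from 3 nM to 40 nM.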

Compound 4, half-maximal inhibitory concentration: 2 nM
Beside the measured number, compound 4's estimate is 5.0-fold (0.70 log units) above it, and the stated range ends above it.
By their numbers in this assay, from the lowest: compounds 4 and 1 (each within the scatter of the next); then compound 3; then compound 2.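

In this assay, the nitrogen of the five-membered aromatic ring accepts oxan-4-yl, with 6 heavy atoms and 1 hydrogen-bond acceptor, in place of cyclopropyl, with 3 heavy atoms and no acceptor, and a 5.0-fold lower number from compound 3 to compound 4 (0.70 log units; beyond the scatter) is the result. Within the data shown here, the earlier compounds compared only cyclopropyl and isopropyl at this position, so this is the first sign that a six-membered ring containing oxygen can sit here without any loss of inhibition. Set against isopropyl, the same group gives a 2.0-fold lower number from compound 1 to compound 4 (0.30 log units; within the scatter) and so cannot be told apart from it, and no available evidence explains either result.

Going by these compounds, whether the oxygen itself matters stays open, since cyclohexyl, the all-carbon ring of the same size, would separate ring size from the oxygen. Piperidin-4-yl, which carries an amine in place of the oxygen, would test how much that ring atom can change.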